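The source may report more compounds than this note shows. Statements on the series, on what has been measured and on what is new or still open speak of the compounds shown alone.

Measured compounds in a functional assay on DU-145 cells (Homo sapiens) for inhibition, read by trypan blue exclusion, with a stated time of 72 h; on this read-out lower numbers stand for stronger inhibition and higher numbers for weaker inhibition:
- compound 1 `Cn1c(=O)c(S(=O)(=O)c2ccc(F)cc2F)cc2cnc(Nc3ccc4[nH]c(C(=O)O)cc4c3)nc21` gives 10000 nM
- compound 2 `Cn1c(=O)c(S(=O)(=O)c2ccc(C(=O)O)cc2)cc2cnc(Nc3ccc4[nH]ccc4c3)nc21` gives 10000 nM
- compound 3 `Cn1c(=O)c(S(=O)(=O)c2ccc(F)cc2F)cc2cnc(Nc3ccncn3)nc21` gives 50000 nM

Compound 2 stands level with compound 1 at the digits shown, the two together the lowest numbers of the three; compound 3 sits a step away, a 5.0-fold higher number from compound 1 to compound 3 (0.70 log units; beyond the scatter), a change at a different place of the core. The untested compound 4 `Cn1c(=O)c(S(=O)(=O)c2ccc(F)cc2)cc2cnc(Nc3ccc4[nH]ccc4c3)nc21` differs from compound 2 by fluoro in place of carboxy on an aromatic carbon. Among the measured compounds shown here, no measured step bears on this change, and compounds 1 and 2, which differ at more than one place, show the same value. An unchanged number is therefore expected, no change at the digits printed from compound 2 to compound 4 (within the scatter). Compound 4 is estimated at 10000 nM, in the range 4000 nM to 25000 nM.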

Compound 4, half-maximal inhibitory concentration: 300 nM
For compound 4 the middle estimate is 33-fold (1.52 log units) above the measured one; the whole stated range lies above it.
By their numbers in this assay, from the lowest: compound 4; then compounds 1 and 2 (each within the scatter of the next); then compound 3.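

In this assay the change from 4-carboxyphenyl to 4-fluorophenyl gives a 33-fold lower number from compound 2 to compound 4 (1.52 log units; beyond the scatter) and so shows that the group on this aromatic carbon, para to a large group, strongly affects the number. The earlier compounds shown here offered no measured step at this place, and this step is larger than the one printed for the other place. No measurement at hand gives a reason for the drop. Still open, as far as these compounds go, is how a methoxy group, an amine or plain hydrogen on this carbon would compare with fluoro.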